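From thiophen-3-yl to 2-hydroxyphenyl: the next step in the series

The source may report more compounds than this note shows. Statements on the series, on what has been measured and on what is new or still open speak of the compounds shown alone.

Values in a functional assay on G-361 cells (Homo sapiens) for inhibition, with a stated time of 72 h (on this read-out higher numbers stand for weaker inhibition and lower numbers for stronger inhibition), so far:
compound 1 `NC1CCC(Nc2nc(NCc3ccc(Br)cc3)c3ncn(C4CCCC4)c3n2)CC1` gives 1480 nM
compound 2 `NC1CCC(Nc2nc(NCc3ccc(-c4ccsc4)cc3)c3ncn(C4CCCC4)c3n2)CC1` gives 570 nM

Compound 2 holds the lower of the two numbers. Within the data shown here, compound 3 `NC1CCC(Nc2nc(NCc3ccc(-c4ccccc4O)cc3)c3ncn(C4CCCC4)c3n2)CC1` has not yet been measured and carries 2-hydroxyphenyl in place of thiophen-3-yl on an aromatic carbon as its only change. Among the measured compounds shown here, one measured step bears on this site: replacing bromo with thiophen-3-yl gave a 2.6-fold lower number from compound 1 to compound 2 (0.41 log units; beyond the scatter) and this step is modest. For the measured compounds named here, no measured compound yet carries 2-hydroxyphenyl, so the data give no firm direction. A step no larger than that modest one is expected, possibly one within the scatter. The estimated step is a 1.1-fold lower number from compound 2 to compound 3 (0.06 log units; within the scatter) on this evidence. For compound 3 the expected value is 500 nM with an estimated range of 200 nM to 1250 nM in this assay for now.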

Compound 3, half-maximal inhibitory concentration: 4150 nM
Compound 3: the middle estimate sits 8.3-fold (0.92 log units) below what was measured; measured number above the stated range.
By their numbers in this assay, from the lowest: compound 2; then compound 1; then compound 3.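

In this assay, this position does not reward every aromatic ring placed on it: 2-hydroxyphenyl in place of thiophen-3-yl gives a 7.3-fold higher number from compound 2 to compound 3 (0.86 log units; beyond the scatter), which reverses the gain seen on leaving bromo. The same group also falls behind bromo itself, with a 2.8-fold higher number from compound 1 to compound 3 (0.45 log units; beyond the scatter), so an aromatic ring at this site can give a higher or a lower number than bromo, depending on which ring enters. No supporting measurement accompanies these numbers, so the data offer no explanation for the reversal.

The compounds shown leave open whether the higher number follows the hydroxyl or the change from the five-membered ring to the six-membered ring, a question that an unsubstituted phenyl would address. Also open, on these data alone, is how this position responds to other groups on the entering ring, such as an aminomethyl or a carboxylic acid.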